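Swapping the amide tail: from phenylpropyl to methylfuran

A few compounds are considered here, and "the series" means these few. Any claim that something is new, unique, unknown or untested is made for them only; others in the source may bear on it.

Compound 3 `O=C(CCCc1ccccc1)Nc1ccc(N2CCN(c3ccc(OC[C@@H]4CO[C@@](Cn5cncn5)(c5ccc(Cl)cc5Cl)O4)cc3)CC2)cc1` carries a (3-phenylpropyl)carbonyl on the amide nitrogen of the shared core. In a functional assay on HepG2 cells (Homo sapiens) for inhibition, read by MTT assay, with a stated time of 48 h (a higher number here means a weaker inhibitor, a lower number a stronger inhibitor), compound 3 gives 10800 nM, the second highest of the three numbers recorded so far. Its nearest neighbour is compound 2 `CCCC(=O)Nc1ccc(N2CCN(c3ccc(OC[C@@H]4CO[C@@](Cn5cncn5)(c5ccc(Cl)cc5Cl)O4)cc3)CC2)cc1`, which in this assay gives 9930 nM; the step of a 1.1-fold higher number from compound 2 to compound 3 (0.04 log units; within the scatter) is within the scatter. Compound 1 `CCCCC(=O)Nc1ccc(N2CCN(c3ccc(OC[C@@H]4CO[C@@](Cn5cncn5)(c5ccc(Cl)cc5Cl)O4)cc3)CC2)cc1` gives 14100 nM in this assay, and the steps of a 1.4-fold lower number from compound 1 to compound 2 (0.15 log units; within the scatter) and a 1.3-fold lower number from compound 1 to compound 3 (0.12 log units; within the scatter) are likewise within the scatter. Compound 4 `Cc1ccc(C(=O)Nc2ccc(N3CCN(c4ccc(OC[C@@H]5CO[C@@](Cn6cncn6)(c6ccc(Cl)cc6Cl)O5)cc4)CC3)cc2)o1` differs from compound 3 in that (5-methylfuran-2-yl in place of 3-phenylpropyl on a carbonyl carbon). The three measured steps all concern this same tail, and none of them moved the number beyond the scatter. The change to compound 4 is larger in kind, exchanging a saturated chain ending in a phenyl for a five-membered aromatic ring with one hetero atom, but nothing measured here points in either direction. The step of a 1.0-fold higher number from compound 3 to compound 4 (0.01 log units; within the scatter) is therefore expected to stay within the scatter. Compound 4 is estimated at 11000 nM in this assay, with a range from 4000 nM to 30000 nM.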

Compound 4, half-maximal inhibitory concentration: 8700 nM
Estimate against measurement, compound 4: 1.3-fold (0.10 log units) above, within the range that was stated.
By their numbers in this assay, from the lowest: compounds 4, 2, 3 and 1 (each within the scatter of the next).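

In this assay, the steps of a 1.2-fold lower number from compound 3 to compound 4 (0.09 log units; within the scatter) and a 1.1-fold lower number from compound 2 to compound 4 (0.06 log units; within the scatter) and also a 1.6-fold lower number from compound 1 to compound 4 (0.21 log units; within the scatter) all stay within the scatter, so the tail on this carbonyl carbon is no longer only a saturated chain. Exchanging 3-phenylpropyl, with its 9 heavy atoms and six-membered aromatic ring of carbon only, for 5-methylfuran-2-yl, with 6 heavy atoms, a five-membered aromatic ring with 1 hetero atom and 1 hydrogen-bond acceptor, leaves all four compounds within the scatter of the next. No evidence is available here to explain this flat result.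

Going by these compounds, it remains open whether a tail carrying an amine or a carboxylic acid, or a chain longer than butyl, would move the number beyond the scatter. The compounds shown also say nothing about a change made anywhere else on the shared core.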